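The compounds below may be only part of what the source reports. "The series", "measured", "known", "first", "only" and "open" are said of these compounds alone.

Measured compounds:
compound 1 `COc1cc(-c2nn(-c3cccc(NC(=O)c4ccc(Cl)c(C(F)(F)F)c4)c3)cc2-c2ccncc2)ccc1Cl` — 1760 nM
compound 2 `O=C(Nc1cccc(-n2cc(-c3ccncc3)c(-c3ccc(Cl)c(O)c3)n2)c1)Nc1cc(C(F)(F)F)cc(C(F)(F)F)c1` — 937 nM

In a functional assay on RXF 393 cells (Homo sapiens) for inhibition, read by sulforhodamine B assay, with a stated time of 48 h (on this read-out lower numbers stand for stronger inhibition of growth and higher numbers for weaker inhibition of growth), compound 1 gives 1760 nM, the higher of the two numbers recorded. Its nearest neighbour is compound 2, which in this assay gives 937 nM; the gap between these two values lies within the usual scatter, so no order between them can be claimed. Going by the values given here, compound 2 carries a urea rather than an amide, together with other differences, so no single-change step is available.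

Compound 3 `COc1cc(-c2nn(-c3cccc(NC(=O)Nc4ccc(Cl)c(C(F)(F)F)c4)c3)cc2-c2ccncc2)ccc1Cl` is not yet measured. It differs from compound 1 in one place: (4-chloro-3-(trifluoromethyl)phenyl)amino in place of 4-chloro-3-(trifluoromethyl)phenyl on a carbonyl carbon. The amide of compound 1 thus becomes a urea in compound 3, the same kind of linkage found in compound 2. Among the compounds with values here, no step between measured compounds isolates this change. Given that compound 2 gives 937 nM, the expectation is a small step from compound 1 to compound 3 of a 1.5-fold lower number from compound 1 to compound 3 (0.17 log units; within the scatter), toward a lower number but not beyond the scatter. Compound 3 is estimated at 1200 nM, with a range from 500 nM to 3000 nM.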

Compound 3, concentration for 50% growth inhibition: 1180 nM
The estimate for compound 3 lay 1.0-fold (0.01 log units) above the measured number; the measured number falls inside the stated range.
By their numbers in this assay, from the lowest: compounds 2, 3 and 1 (each within the scatter of the next).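

Going by these compounds alone, the amide-to-urea change on this carbonyl carbon can now be read on its own, which the earlier compounds did not allow: in this assay the core of compound 1 is kept and the step is a 1.5-fold lower number from compound 1 to compound 3 (0.17 log units; within the scatter), within the scatter. The entering (4-chloro-3-(trifluoromethyl)phenyl)amino group counts a hydrogen-bond donor that the leaving 4-chloro-3-(trifluoromethyl)phenyl group lacks, yet this single step shows no change that can be told from the scatter. Nothing measured here explains this outcome.

As far as these compounds go, whether a sulfonamide or a carbamate at this place would give a number clearly apart from these stays open. Also open, from the compounds shown here alone, is whether a longer chain on the carbonyl carbon would leave the number within the scatter of compound 1 as well.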